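The compounds below may be only part of what the source reports. "The series", "measured", "known", "first", "only" and "open" are said of these compounds alone.

In a functional assay on VCaP cells (Homo sapiens) for antiproliferative activity, read by propidium iodide staining, with a stated time of 96 h (on this read-out lower numbers stand for stronger inhibition and higher numbers for weaker inhibition), compound 1 `CC(O)(COc1ccc(C(F)(F)F)cc1)C(=O)Nc1cccc(S(F)(F)(F)(F)F)c1` gives 13300 nM and compound 2 `CC(O)(COc1ccccc1C(F)(F)F)C(=O)Nc1cccc(S(F)(F)(F)(F)F)c1` gives 36700 nM as the higher of the two numbers. Compound 3 `CC(O)(COc1ccccc1OC(F)(F)F)C(=O)Nc1cccc(S(F)(F)(F)(F)F)c1` carries trifluoromethoxy in place of trifluoromethyl on an aromatic carbon with the rest unchanged. Going by the values given here, no measured step tests this exchange directly. The nearest evidence is a 2.8-fold higher number from compound 1 to compound 2 (0.44 log units; beyond the scatter) for 2-(trifluoromethyl)phenyl in place of 4-(trifluoromethyl)phenyl, a modest move at the same ring. The expected outcome is a 1.2-fold lower number from compound 2 to compound 3 (0.09 log units; within the scatter) in this assay with no clear direction and probably nothing beyond the scatter. Compound 3 is estimated at 30000 nM within a range from 13000 nM to 65000 nM for now.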

Compound 3, half-maximal inhibitory concentration: 27700 nM
For compound 3 the middle estimate is 1.1-fold (0.03 log units) above the measured one, and the stated range covers the measured number.
By their numbers in this assay, from the lowest: compound 1; then compounds 3 and 2 (each within the scatter of the next).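

In this assay the exchange of trifluoromethyl for trifluoromethoxy on an aromatic carbon, ortho to a large group, gives a 1.3-fold lower number from compound 2 to compound 3 (0.12 log units; within the scatter). At this position the two groups therefore cannot be told apart, and the added oxygen, with its hydrogen-bond acceptor, moves the number nothing beyond the scatter. Nothing available bears on why the exchange is so quiet. Open, as far as these compounds go, is whether trifluoromethoxy stays equally silent in the place the trifluoromethyl holds in compound 1. Also open, from the compounds shown here alone, is whether a nitrile, a chlorine or an amine at this ring carbon would depart from these numbers.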